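The source may hold more compounds than are shown below. What is called first, only, known or untested is meant among the compounds shown, and "the series" means these compounds.

Measured so far, all in the same binding assay:

Compound 1, `CCC(C)OC(=O)C1=C(C)NC(=O)NC1c1cccs1`: 7%
Compound 2, `CC1=C(C(=O)OC2CCCCC2)C(c2cccs2)NC(=O)N1`: 3%
Compound 3, `CCC(C)OC(=O)C1=C(C)NC(=O)NC1c1ccsc1`: 39%

The three compounds share one core and differ in two places. In a binding assay on membranes from HEK293 cells for displacement of a labelled ligand from adenosine receptor A2b (Homo sapiens), read by scintillation counting, with a stated time of 30 min, tested at 1 uM (on this read-out lower numbers stand for less inhibition and higher numbers for more inhibition at the one concentration tested (going by the name of the read-out)), compound 1 gives 7%. Compound 2 carries the change cyclohexyl in place of sec-butyl on an oxygen next to a carbonyl group and gives 3%; the step is a number 4 percentage points lower from compound 1 to compound 2 (within the scatter). Compound 3 differs from compound 1 by thiophen-3-yl in place of thiophen-2-yl on a saturated ring carbon, and compound 3 gives 39%; that step is a number 32 percentage points higher from compound 1 to compound 3 (beyond the scatter), and compound 3 is the highest of the three, beyond the scatter against both compound 1 and compound 2.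

Compound 4, `CC1=C(C(=O)OC2CCCCC2)C(c2ccsc2)NC(=O)N1`, has not yet been measured in this assay. It is built from compound 3 by cyclohexyl in place of sec-butyl on an oxygen next to a carbonyl group. This is the same change that turns compound 1 into compound 2, made at the same place on the molecule; what differs is the core on which it is made, and the two cores differ by the thiophene attachment just described.

Since that change moved the read-out only within the scatter when applied to compound 1, the expectation is that it does much the same when applied to compound 3. Compound 4 is therefore estimated to sit close to compound 3, at about 35%, with the plausible range running from 15% to 55%. Expressed as a step, the expected change from compound 3 to compound 4 is a number 4 percentage points lower from compound 3 to compound 4 (within the scatter), which rests on the single earlier measured example of this change, a number 4 percentage points lower from compound 1 to compound 2 (within the scatter), and carries the uncertainty of resting on one pair alone.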

Compound 4, a percentage reported as inhibition, at one concentration (the size of the read-out at that concentration, not a potency): 4%
The estimate for compound 4 lay 31 percentage points above the measured number; the measured number lies below the stated range.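

Cyclohexyl in place of sec-butyl does not carry over unchanged from one core to the other in this assay, since on the core of compound 3 it gives a number 35 percentage points lower from compound 3 to compound 4 (beyond the scatter), and the two examples of this change disagree: the same change on two cores in this assay, a number 4 percentage points lower (within the scatter) from compound 1 to compound 2 and a number 35 percentage points lower (beyond the scatter) from compound 3 to compound 4, 31 percentage points apart, beyond the scatter of two such steps

Thiophen-3-yl in place of thiophen-2-yl also depends on its surroundings, as with cyclohexyl already in place it gives only a number 1 percentage points higher from compound 2 to compound 4 (within the scatter), and the two examples of this change disagree as well: the same change on two cores in this assay, a number 32 percentage points higher (beyond the scatter) from compound 1 to compound 3 and a number 1 percentage points higher (within the scatter) from compound 2 to compound 4, 31 percentage points apart, beyond the scatter of two such steps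

The two changes therefore cannot be treated as independent here, with the high number of compound 3, at 39%, appearing only where sec-butyl and thiophen-3-yl occur together, but these four compounds do not show why that is, or whether the same holds for any other pair of groups.

Going by these compounds, it remains open whether an isopropyl group, a cyclopentyl group or a longer chain such as n-butyl on the same oxygen would behave like sec-butyl or like cyclohexyl on the thiophen-3-yl core. On these data alone, it also remains open whether a phenyl ring in place of the thiophene would keep the higher number seen for compound 3.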